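One Thiosemicarbazone Swap Tried on Two Different Cores

This account rests on a few compounds, and the source may have more. Where it says the series, first, only, none or still open, it means among the compounds named here.

Measured compounds:
compound 1, `CN(C)C(=S)N/N=C/c1ccc2cccnc2n1`: 560 nM
compound 2, `NC(=S)N/N=C/c1ccc2cccnc2n1`: a limit, > 100000 nM
compound 3, `NC(=S)N/N=C/c1nc2ccccc2s1`: a limit, > 100000 nM

In a functional assay on HL-60 cells (Homo sapiens) for antiproliferative activity, read by sulforhodamine B assay, with a stated time of 72 h (a lower number here means a stronger inhibitor, a higher number a weaker inhibitor), compound 1 gives 560 nM. Compound 2 shows only a limit here, > 100000 nM. Compound 3 likewise shows only a limit, > 100000 nM. Compound 2 and compound 1 differ in one place, (dimethylamino in place of amino on a thiocarbonyl carbon), and that change made the step of an at least 170-fold lower number from compound 2 to compound 1 (2.25 log units; beyond the scatter), whose size is known only as a bound because of the limit of > 100000 nM in this assay, at which 2 of the 3 values shown sit. The same kind of change leads from compound 3 to compound 4, `CN(C)C(=S)N/N=C/c1nc2ccccc2s1`: dimethylamino in place of amino on a thiocarbonyl carbon. The difference between the two cores is not broken down here. Resting on the measured step of an at least 170-fold lower number from compound 2 to compound 1 (2.25 log units; beyond the scatter), a step of comparable size is expected, an at least 66-fold lower number from compound 3 to compound 4 (1.82 log units; beyond the scatter). Compound 4 is therefore estimated at 1500 nM, between 200 nM and 20000 nM.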

Compound 4, half-maximal inhibitory concentration: 3680 nM
The estimate for compound 4 lay 2.5-fold (0.39 log units) below the measured number; the measured number falls inside the stated range.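

The change carried over to the second core: in this assay, dimethylamino in place of amino on a thiocarbonyl carbon again gave a large step, an at least 27-fold lower number from compound 3 to compound 4 (1.43 log units; beyond the scatter). This shows the same direction on both cores, but it does not show whether the change is worth the same amount on each: the same change on two cores in this assay, an at least 170-fold lower number (2.25 log units; beyond the scatter) from compound 2 to compound 1 and an at least 27-fold lower number (1.43 log units; beyond the scatter) from compound 3 to compound 4; the limit leaves it open whether they differ. From the compounds shown here alone, the true size of each step also stays unknown, because each one starts from a compound that shows only a limit: the limit of > 100000 nM in this assay, at which 2 of the 4 values shown sit.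

The compounds shown leave open whether the same step would appear on a third core. They also leave open what a group of intermediate or larger size on the thiocarbonyl carbon, such as methylamino or diethylamino, would give.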